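The source may hold more compounds than are shown below. What is called first, only, known or untested is meant among the compounds shown, and "the series" means these compounds.

Measured compounds:
compound 1 `CC1CCN(C2CCN(S(=O)(=O)c3cccnc3)CC2)CC1`: > 10000 nM
compound 2 `Cc1cc(C)c(S(=O)(=O)N2CCC(N3CCCCCC3)CC2)c(C)c1`: > 5000 nM
compound 3 `COc1ccc(NS(=O)(=O)N2CCC(N3CCC(C)CC3)CC2)cc1`: > 5000 nM

All three were tested in an ADME assay on HCT-116 cells (Homo sapiens) for cytotoxicity, read by CellTiter-Glo, with a stated time of 72 h; a lower number here means a stronger inhibitor, a higher number a weaker inhibitor. For compound 1 the result is only a limit, > 10000 nM, so no number is known for it. Compound 2 likewise gives only a limit, > 5000 nM. Compound 3 also gives only a limit, > 5000 nM. Compound 1 sits at the limit of > 10000 nM in this assay, at which 1 of the 3 values shown sits, the other two at the limit of > 5000 nM in this assay, at which 2 of the 3 values shown sit. No two of these compounds differ in just one place, so no measured step size exists. Compound 4 `Cc1nc(Cl)sc1S(=O)(=O)N1CCC(N2CCC(C)CC2)CC1` is not yet measured in this assay. It differs from compound 1 in one place: 2-chloro-4-methyl-1,3-thiazol-5-yl in place of pyridin-3-yl on a sulfonyl sulfur. With every value shown being a limit, the step that the limit leaves unreadable from compound 1 to compound 4 is expected to stay within the scatter. Compound 4 is estimated at 15000 nM, in a range from 5000 nM to 50000 nM.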

Compound 4, half-maximal inhibitory concentration: > 10000 nM
Compound 4: a limit, no number; the forecaster's own chance of this, stated with the estimate: 85%; the middle value does not contradict the limit.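

Compound 1 and compound 4 both give only a limit in this assay, so the step between them cannot be read. The compounds shown leave open the actual inhibitory concentration of each, as all four results are limits, not numbers.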